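Two Substituents and Half-life

The compounds below may be only part of what the source reports. "The series", "measured", "known", "first", "only" and "open" are said of these compounds alone.

Compound 1 `O=C(NCCCCc1ccccc1)n1cc(-c2ccccc2)oc1=O` is the smallest member of the set. In an ADME assay on a cell-free system (plasma, Mus musculus) for metabolic stability, read by LC-MS, tested at 2 uM (a higher number here means that the compound lasts longer, a lower number that the compound disappears faster), compound 1 reaches only a limit, < 0.0834 h. Compound 2 `O=C(NCCCCc1ccccc1)n1cc(-c2ccc(F)cc2)oc1=O` carries fluoro in place of hydrogen on an aromatic carbon. In this assay compound 2 gives 1.5 h. That change brought an at least 17-fold higher number from compound 1 to compound 2 (1.25 log units; beyond the scatter). Compound 3 `CN1CCC(c2cccc(-c3cn(C(=O)NCCCCc4ccccc4)c(=O)o3)c2)CC1` carries 1-methylpiperidin-4-yl in place of hydrogen on an aromatic carbon. In this assay compound 3 sits at a limit, > 2 h. That change brought an at least 23-fold higher number from compound 1 to compound 3 (1.37 log units; beyond the scatter); the step can only be given as a minimum because compound 1 sits at the limit of < 0.0834 h in this assay, at which 1 of the 3 values shown sits, and because compound 3 sits at the limit of > 2 h in this assay, at which 1 of the 3 values shown sits.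

Compound 4 `CN1CCC(c2cc(F)ccc2-c2cn(C(=O)NCCCCc3ccccc3)c(=O)o2)CC1` is not yet measured. It differs from compound 2 by 1-methylpiperidin-4-yl in place of hydrogen on an aromatic carbon. Among the measured compounds shown here, this is the same kind of change as the one from compound 1 to compound 3, but not the same: in compound 3 the entering group stands meta to a large group, whereas in compound 4 it stands ortho to a large group and meta to a fluoro group. The cores of compound 2 and compound 4 differ from those of compound 1 and compound 3 by fluoro in place of hydrogen on an aromatic carbon.

The same kind of change has been made once before, from compound 1 to compound 3, with an at least 23-fold higher number from compound 1 to compound 3 (1.37 log units; beyond the scatter). Since compound 2 already gives 1.5 h, the author expects a smaller gain from compound 2 to compound 4, a 2.0-fold higher number from compound 2 to compound 4 (0.30 log units; within the scatter), in this assay. For compound 4 the author estimates 3 h in this assay, between 1.2 h and 8 h.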

Compound 4, half-life: > 2 h
Compound 4: no number, only a limit (the forecaster's own chance of this, stated with the estimate: 60%); the middle value does not contradict the limit.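

In this assay compound 4 gives > 2 h, which is a limit and not a number. The new step can therefore be read only as a floor, an at least 1.3-fold higher number from compound 2 to compound 4 (0.12 log units; that floor lies within the scatter), so it shows that compound 4 keeps up with compound 2 once 1-methylpiperidin-4-yl enters on the fluoro-bearing core, but it does not show how large any gain is. Carrying the change from the core of compound 1 to the core of compound 2 thus goes with a higher number on the first core and no measured drop on the second, while neither a matching size nor a different size of effect can be claimed: the same change on two cores in this assay, an at least 23-fold higher number (1.37 log units; beyond the scatter) from compound 1 to compound 3 and an at least 1.3-fold higher number (0.12 log units; that floor lies within the scatter) from compound 2 to compound 4; the limit leaves it open whether they differ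

The compounds shown leave open how long compound 3 and compound 4 actually last, since both end at the same limit of the assay: the limit of > 2 h in this assay, at which 2 of the 4 values shown sit. They also leave open whether a different amine such as morpholine, a carboxylic acid or a longer chain in place of 1-methylpiperidin-4-yl would give a half-life that can be read as a number on either core.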